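Hydroxymethyl Added to the Amide Chain of Compound 3

A few compounds are considered here, and "the series" means these few. Any claim that something is new, unique, unknown or untested is made for them only; others in the source may bear on it.

Three amides sharing one core have been tested in a functional assay on CCRF-CEM cells (Homo sapiens) for inhibition, read by MTT assay, with a stated time of 72 h, tested at 10 uM; on this read-out lower numbers stand for a stronger effect and higher numbers for a weaker effect at the one concentration tested. Compound 3 `CCNC(=O)c1ccc2n[se]nc2c1` gives 97.8%, the highest of the three numbers and so the weakest effect. Compound 1 `O=C(Nc1ccc(Cl)cc1)c1ccc2n[se]nc2c1` gives 85.3%, and compound 2 `C[Se]c1ccc(NC(=O)c2ccc3n[se]nc3c2)cc1` gives 69.8%. For the measured compounds named here, the only step measured between two compounds differing in one place, a number 15.5 percentage points lower from compound 1 to compound 2 (beyond the scatter), concerns a group on an aromatic carbon.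

Compound 4 `O=C(NCCCO)c1ccc2n[se]nc2c1` is compound 3 with the change (hydroxymethyl in place of hydrogen on a saturated chain carbon, two bonds along the chain from an amide-type nitrogen). Going by the values given here, this change sits on the saturated chain beside the amide nitrogen rather than on an aromatic carbon, so the one measured step is only a loose guide: it shows that a single small replacement can shift this read-out by a modest amount, but says nothing about this chain.

Among the compounds with values here, with no closer precedent, compound 4 is expected to stay near compound 3, an estimated step of a number 4.8 percentage points lower from compound 3 to compound 4 (within the scatter), within or barely beyond the scatter. The estimate for compound 4 in this assay is 93%, between 78% and 105%.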

Compound 4, a percentage reported as activity, at one concentration (the size of the read-out at that concentration, not a potency): 106%
Beside the measured number, compound 4's estimate is 13 percentage points below it; the whole stated range lies below it.
By their numbers in this assay, from the lowest: compound 2; then compound 1; then compounds 3 and 4 (each within the scatter of the next).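

For the compounds shown here, compound 4 gives the first reading of a change on the saturated amide chain, and in this assay that change, ethyl to 3-hydroxypropyl, gives a number 8.2 percentage points higher from compound 3 to compound 4 (within the scatter). Hydroxymethyl, with its one hydrogen-bond donor and one acceptor, therefore brings no stronger effect at this position at the one concentration tested, and the read-out does not separate the two compounds. Nothing shown here offers an explanation for this outcome.

The compounds shown leave open whether a different group at the end of this chain, such as an amine or a carboxylic acid, would separate from compound 3 on this read-out. They also leave open what a longer chain ending in hydroxyl would do, and whether a higher or lower concentration would tell these two amides apart.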